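From anilino to (4-bromophenyl)amino on the shared core

A few compounds are considered here, and "the series" means these few. Any claim that something is new, unique, unknown or untested is made for them only; others in the source may bear on it.

In a functional assay on MGC-803 cells (Homo sapiens) for inhibition, read by sulforhodamine B assay (a higher number here means a weaker inhibitor, a lower number a stronger inhibitor), compound 2 `O=C1C(Nc2ccccc2)=CC(=O)c2c1nc1n2[C@H]2OC[C@@H](O)[C@H]2OC1` gives 1830 nM and compound 1 `O=C1C(Nc2ccc(I)cc2)=CC(=O)c2c1nc1n2[C@H]2OC[C@@H](O)[C@H]2OC1` gives 2150 nM, so the two lie within the scatter of each other. Compound 3 `O=C1C=C(N2CCC2)C(=O)c2c1nc1n2[C@H]2OC[C@@H](O)[C@H]2OC1` gives > 16000 nM, which is a limit and not a number.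

Compound 4 `O=C1C(Nc2ccc(Br)cc2)=CC(=O)c2c1nc1n2[C@H]2OC[C@@H](O)[C@H]2OC1` differs from compound 2 by bromo in place of hydrogen on an aromatic carbon, para to a large group. Going by the values given here, the one measured step that bears on this is hydrogen in place of iodo on an aromatic carbon, a 1.2-fold lower number from compound 1 to compound 2 (0.07 log units; within the scatter), and it stays within the scatter. No change beyond the scatter is therefore expected in this assay. The expected step is a 1.1-fold higher number from compound 2 to compound 4 (0.04 log units; within the scatter). Compound 4 is estimated at 2000 nM, with an expected range of 1050 nM to 3800 nM.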

Compound 4, half-maximal inhibitory concentration: 2020 nM
The estimate for compound 4 lay 1.0-fold (0.00 log units) below the measured number, and the stated range covers the measured number.
By their numbers in this assay, from the lowest: compounds 2, 4 and 1 (each within the scatter of the next). At a limit, above all of these: compound 3.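

In this assay, the new bromo compound gives two steps, a 1.1-fold higher number from compound 2 to compound 4 (0.04 log units; within the scatter) and a 1.1-fold lower number from compound 1 to compound 4 (0.03 log units; within the scatter). Hydrogen, bromo and iodo on this aromatic carbon, para to a large group, now all lie within the scatter of one another, where the earlier compounds offered only the hydrogen and iodo pair.

Open, from the compounds shown here alone, is whether an amine, a carboxylic acid or a methoxy group at this same place would move the number beyond the scatter. Compound 3 gives > 16000 nM, which is a limit and not a number, so steps to it cannot be read: the limit of > 16000 nM in this assay, at which 1 of the 4 values shown sits.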